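The compounds below may be only part of what the source reports. "The series", "measured", "known", "first", "only" and "open" are said of these compounds alone.

Three compounds have so far been measured in a functional assay on NSCLC cells (Homo sapiens) for inhibition, with a stated time of 48 h; a higher number here means a weaker inhibitor of growth, a lower number a stronger inhibitor of growth:
Compound 1, `COc1cc2c(/C=C3/C(=O)N(C)c4ccccc43)c(Cl)n(C)c2cc1C`, gives 580 nM.
Compound 2, `COc1cc2c(/C=C3/C(=O)N(C)c4ccc(O)cc43)c(Cl)n(C)c2cc1C`, gives 220 nM.
Compound 3, `COc1cc2c(/C=C3/C(=O)N(C)c4ccccc43)c[nH]c2cc1C`, gives 6310 nM.

Compound 1 and compound 2 share one core and differ only by hydroxy in place of hydrogen on an aromatic carbon. That single change produced a 2.6-fold lower number from compound 1 to compound 2 (0.42 log units; beyond the scatter). Compound 3 is built on a different core; the difference between the two cores is not broken down here, and compound 3 stands as the highest number of the three.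

Compound 4, `COc1cc2c(/C=C3/C(=O)N(C)c4ccc(O)cc43)c[nH]c2cc1C`, is not yet measured. It applies the same change to compound 3 that turned compound 1 into compound 2: hydroxy in place of hydrogen on an aromatic carbon. The place of the change is the same in both pairs.

A step of a 2.6-fold lower number from compound 3 to compound 4 (0.42 log units; beyond the scatter) is expected for compound 4 because the identical change earlier gave a 2.6-fold lower number from compound 1 to compound 2 (0.42 log units; beyond the scatter). Compound 4 is therefore estimated at 2400 nM, expected to fall between 1000 nM and 6000 nM.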

Compound 4, concentration for 50% growth inhibition: 6030 nM
The estimate for compound 4 lay 2.5-fold (0.40 log units) below the measured number, and the stated range ends below it.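

The step of a 1.0-fold lower number from compound 3 to compound 4 (0.02 log units; within the scatter) in this assay means that the hydroxy made no readable difference on the core of compound 3, although the same change gave a step beyond the scatter on the core of compound 1. Set side by side, however, the two steps cannot be told apart: the same change on two cores in this assay, a 2.6-fold lower number (0.42 log units; beyond the scatter) from compound 1 to compound 2 and a 1.0-fold lower number (0.02 log units; within the scatter) from compound 3 to compound 4, 2.5-fold (0.40 log units) apart, within the scatter of two such steps. This single pair therefore neither shows that the gain carries over to the second core nor proves that it is lost there, and it gives no reason for either outcome.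

The compounds shown leave open whether an amine or a carboxylic acid in place of the hydroxy would change the number on either core.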